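A few compounds are considered here, and "the series" means these few. Any claim that something is new, unique, unknown or untested is made for them only; others in the source may bear on it.

Measured compounds:
compound 1, `O=C(c1ccco1)N1CCN(c2cnn(CCCCCCCN3CCN(c4ccccc4Cl)CC3)c(=O)c2Cl)CC1`, in an assay on cell membranes for binding affinity to Adrenergic receptor alpha-1 (Rattus norvegicus), read by radioligand binding (on this read-out higher numbers stand for weaker inhibition and lower numbers for stronger inhibition), compound 1 gives 11.5 nM
compound 2, `COc1ccccc1N1CCN(CCCCCn2nc(N3CCN(C(=O)c4ccco4)CC3)ccc2=O)CC1`, in this assay compound 2 gives 43.7 nM

Among the compounds with values here, compound 2 stands at the higher of the two numbers known so far; its nearest neighbour is compound 1, whose value sits lower by a gap that lies beyond the usual scatter of repeated measurements. Within the data shown here, compound 1 and compound 2 differ in more than one place, so no single step between them can be read from the pair; only their two values are known.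

The unmeasured compound 3, `O=C(c1ccco1)N1CCN(c2ccc(=O)n(CCCCCN3CCN(c4ccccc4Cl)CC3)n2)CC1`, is reached from compound 2 by one change: chloro in place of methoxy on an aromatic carbon. Among the measured compounds shown here, no pair of measured compounds isolates this change, so the size of the step is open. For the measured compounds named here, the only pointer is compound 1, which also carries a 2-chlorophenyl group and gives 11.5 nM, though it differs from compound 3 in other places as well. The account therefore expects a step of a 1.7-fold lower number from compound 2 to compound 3 (0.24 log units; within the scatter), toward a lower number, of modest size and possibly not beyond the scatter. For compound 3 the estimate is 25 nM, with a range from 8 nM to 70 nM.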

Compound 3, inhibition constant: 13.3 nM
The estimate for compound 3 lay 1.9-fold (0.27 log units) above the measured number; the measured number falls inside the stated range.
By their numbers in this assay, from the lowest: compounds 1 and 3 (each within the scatter of the next); then compound 2.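

In this assay, the move from 2-methoxyphenyl to 2-chlorophenyl, on an aromatic carbon ortho to a large group, gives a 3.3-fold lower number from compound 2 to compound 3 (0.52 log units; beyond the scatter) with the rest of the structure unchanged. Within the data shown here, this is the first step here that isolates a single change, and it shows that this one position can by itself shift the number beyond the scatter, by a modest amount, with chloro on the lower side of methoxy. The data shown offer no measured property that would explain this step.

Going by these compounds, whether the shift belongs to chloro in particular remains open, since a fluoro, a methyl, a trifluoromethyl or an unsubstituted phenyl at this place would be needed to show how the number follows the group, and the step holds for a single pair on a single core. The separate effects of a longer chain and of the chloro on the core of compound 1 cannot be read, as compound 1 differs from both compound 2 and compound 3 in more than one place.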